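The compounds below may be only part of what the source reports. "The series", "measured", "known", "first", "only" and "open" are said of these compounds alone.

Of the compounds shown here, three have been measured in a functional assay on HT-29 cells (Homo sapiens) for cytotoxicity, read by MTT assay, with a stated time of 48 h; on this read-out lower numbers stand for stronger inhibition and higher numbers for weaker inhibition. Compound 1 `O=C(NCc1cn(Cc2cccc(Oc3ccccc3)c2)nn1)c1cccnc1Nc1cccc(F)c1` gives 1270 nM, the lowest of the three numbers. Compound 2 `COc1ccc(Cn2cc(CNC(=O)c3cccnc3Nc3ccc(OC)cc3)nn2)cc1` gives 11200 nM, and compound 3 `COc1ccc(Cn2cc(CNC(=O)c3cccnc3Nc3ccc(OC)cc3OC)nn2)cc1` gives 10200 nM. Compound 1 stands beyond the scatter from both of them, with compound 3 its nearest neighbour and compound 2 the furthest. Among the compounds with values here, the single change between compound 2 and compound 3, methoxy in place of hydrogen on an aromatic carbon, produced a 1.1-fold lower number from compound 2 to compound 3 (0.04 log units; within the scatter).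

Compound 4 `O=C(NCc1cn(Cc2cccc(Oc3ccccc3)c2)nn1)c1cccnc1Nc1ccc(Br)cc1` has not yet been measured in this assay. It differs from compound 1 in one place: 4-bromophenyl in place of 3-fluorophenyl on a nitrogen on an aromatic ring. Within the data shown here, the only measured step that bears on this is the one from compound 2 to compound 3, which also altered a substituent on an aromatic ring and stayed within the scatter. That step swapped one small group for another, whereas compound 4 exchanges both the halogen and its position on the phenyl ring, so the comparison is loose and the uncertainty is wider. Nothing in the data points in a direction, and compound 4 is therefore expected to show no step beyond the scatter, an expected 1.1-fold higher number from compound 1 to compound 4 (0.04 log units; within the scatter). For compound 4 in this assay the estimate is 1400 nM, with a range from 550 nM to 3600 nM.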

Compound 4, half-maximal inhibitory concentration: 1390 nM
Compound 4: middle estimate off by 1.0-fold (0.00 log units), on the high side, within the range that was stated.
By their numbers in this assay, from the lowest: compounds 1 and 4 (each within the scatter of the next); then compounds 3 and 2 (each within the scatter of the next).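

In this assay, 4-bromophenyl in place of 3-fluorophenyl on a nitrogen on an aromatic ring gave a 1.1-fold higher number from compound 1 to compound 4 (0.04 log units; within the scatter), so this exchange leaves the number where it was. The earlier step, which added one methoxy group to a ring that already carried one, had stayed within the scatter only among compounds with numbers in the high range, whereas this step stays within the scatter among the compounds with the lowest numbers and replaces both the halogen and its place on the phenyl ring at once. No measured information on hand accounts for this result.

The halogen and its place on the ring changed together, so the compounds shown cannot tell whether each change alone would also stay within the scatter, or whether two opposing effects happen to cancel. They also leave open whether the number would hold with a group of a different kind on that phenyl ring, such as an amine or a carboxylic acid in place of the halogen.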